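The source may report more compounds than this note shows. Statements on the series, on what has been measured and on what is new or still open speak of the compounds shown alone.

Measured so far in an assay on HL-60 cells for inhibition of glutathione S-transferase P (Homo sapiens), read by spectrophotometry, tested at 5 uM; a higher number here means more inhibition at the concentration tested (going by the name of the read-out), a lower number less inhibition:
compound 1 `C=C(CC)C(=O)c1ccc(OCc2nc(-c3ccc([N+](=O)[O-])cc3)cs2)cc1Cl`, 10.2%
compound 2 `C=C(CC)C(=O)c1ccc(OCc2nc(-c3ccc4ccccc4c3)cs2)cc1Cl`, 9.5%
compound 3 `C=C(C)C(=O)c1ccc(OCc2nc(-c3ccc4ccccc4c3)cs2)cc1Cl`, 55.2%

Compound 2 gives the lowest of these three numbers. The nearest of the others is a number 0.7 percentage points lower from compound 1 to compound 2 (within the scatter), and the furthest is a number 45.7 percentage points higher from compound 2 to compound 3 (beyond the scatter). Compound 4 `C=C(CC)C(=O)c1ccc(OCc2nc(-c3ccc4ccccc4c3)cs2)c(Cl)c1Cl` differs from compound 2 by a single change: chloro in place of hydrogen on an aromatic carbon. Neither measured step concerns a change of this kind: one concerns naphthalen-2-yl in place of 4-nitrophenyl, the other hydrogen in place of methyl. Among the compounds with values here, no measured step therefore speaks to a chloro group entering here, and with nothing to go on, no shift beyond the scatter in this assay is expected. Compound 4 is estimated at 10%, within 0% to 28%, which would mean an expected step of a number 0.5 percentage points higher from compound 2 to compound 4 (within the scatter).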

Compound 4, a percentage reported as inhibition, at one concentration (the size of the read-out at that concentration, not a potency): 4.3%
Beside the measured number, compound 4's estimate is 5.7 percentage points above it; measured number inside the range.
By their numbers in this assay, from the lowest: compounds 4, 2 and 1 (each within the scatter of the next); then compound 3.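

In this assay, placing a chloro group on the aromatic carbon ortho to the existing chloro group gives a number 5.2 percentage points lower from compound 2 to compound 4 (within the scatter). Within the data shown here, this is the first reading at this position, and it shows no shift that can be told from the scatter, though compound 2 already sits low, so little room for a further fall remains. Nothing measured here bears on the reason for this result.

Still open, from the compounds shown here alone, is whether a methoxy group or an amine on this carbon would read differently, and whether the same chloro group would leave compound 3 unmoved.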